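From an Ester to a Chlorobenzyl Ether on the Shared Core

A few compounds are considered here, and "the series" means these few. Any claim that something is new, unique, unknown or untested is made for them only; others in the source may bear on it.

Compound 1 `C=CCOc1ccc2c(=O)c(-c3cc(OC)c(OC)cc3OC)coc2c1` gives 5100 nM in a functional assay on B16 cells (Mus musculus) for antiproliferative activity, read by MTT assay, with a stated time of 24 h; a lower number here means a stronger inhibitor, a higher number a weaker inhibitor.
Compound 2 `COc1cccc(C(=O)Oc2ccc3c(=O)c(-c4cc(OC)c(OC)cc4OC)coc3c2)c1` gives > 10000 nM, which is a limit of the assay.
Compound 3 `COc1cc(OC)c(-c2coc3cc(OCc4ccccc4C(F)(F)F)ccc3c2=O)cc1OC` gives 8550 nM.

Compound 2 thus stands at the edge of what this assay reports: the limit of > 10000 nM in this assay, at which 1 of the 3 values shown sits. Compound 4 `COc1cc(OC)c(-c2coc3cc(OCc4ccc(Cl)cc4)ccc3c2=O)cc1OC` has not yet been measured. It differs from compound 2 in one place: 4-chlorobenzyl in place of (3-methoxyphenyl)carbonyl on an oxygen on an aromatic ring. The closest measured parallel is the step to the other benzyl ether, an at least 1.1-fold lower number from compound 2 to compound 3 (0.06 log units; that floor lies within the scatter), which only sets a floor. The two ethers of the shared core sit close to each other, as a 1.7-fold higher number from compound 1 to compound 3 (0.22 log units; within the scatter) shows, while the ester gives the limit, as an at least 1.9-fold higher number from compound 1 to compound 2 (0.29 log units; that floor lies within the scatter) shows. On this basis compound 4 is expected to land near compound 3 rather than at the limit, so the estimated step is an at least 1.2-fold lower number from compound 2 to compound 4 (0.09 log units; that floor lies within the scatter). Compound 4 is therefore estimated at 8000 nM, with a range from 3500 nM to 18000 nM.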

Compound 4, half-maximal inhibitory concentration: 2400 nM
Compound 4: middle estimate off by 3.3-fold (0.52 log units), on the high side; measured number outside the range, below it.
By their numbers in this assay, from the lowest: compound 4; then compounds 1 and 3 (each within the scatter of the next). At a limit, above all of these: compound 2.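

In this assay, the 4-chlorobenzyl ether separates beyond the scatter from both other ethers on this oxygen, a 3.6-fold lower number from compound 3 to compound 4 (0.55 log units; beyond the scatter) and a 2.1-fold lower number from compound 1 to compound 4 (0.33 log units; beyond the scatter), whereas the earlier pair of ethers stayed within it, a 1.7-fold higher number from compound 1 to compound 3 (0.22 log units; within the scatter). Replacing the ester gives an at least 4.1-fold lower number from compound 2 to compound 4 (0.61 log units; beyond the scatter), and this step is only a floor. Compound 2 stands at a limit of the assay, not at a number: the limit of > 10000 nM in this assay, at which 1 of the 4 values shown sits.

The 4-chlorophenyl and 2-(trifluoromethyl)phenyl groups differ both in the substituent and in where it sits, so the step between them does not show which of the two counts. From the compounds shown here alone, how an unsubstituted benzyl, or a benzyl carrying an amine or a carboxylic acid, would read on this oxygen also stays open.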